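The source may report more compounds than this note shows. Statements on the series, on what has been measured and on what is new or still open speak of the compounds shown alone.

Compound 1 `COc1ncc(-c2ccccc2)cc1[C@@H](c1ccccc1)[C@@](O)(CCN(C)C)c1cc(F)ccc1F` has been tested for harm to cells in a toxicity assay on Vero cells (Chlorocebus sabaeus) for cytotoxicity; a higher number here means that more compound is tolerated, a lower number that less compound is tolerated. There, compound 1 gives > 50 ug/mL, which is a limit of the assay and not a number. Compound 2 `COc1nc(-c2ccncc2)ccc1[C@@H](c1ccccc1)[C@@](O)(CCN(C)C)c1cccc2ccccc12` gives > 50 ug/mL in this assay, and this too is a limit. Within the data shown here, the record so far therefore reads (the limit of > 50 ug/mL in this assay, at which 2 of the 2 values shown sit), so compound 1 has no exact value to be ranked by, and no measured pair shows the size of any structural step.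

Compound 3 `COc1ncc(-c2ccccc2)cc1[C@@H](c1ccccc1)[C@@](O)(CCN(C)C)c1ccccc1` keeps the core of compound 1 and changes one group: phenyl in place of 2,5-difluorophenyl on a saturated chain carbon bound to an oxygen on a saturated carbon and two saturated chain carbons. Among the measured compounds shown here, with no measured step to guide the estimate, no shift beyond the usual scatter is expected in either direction. The expected change is a step that the limit leaves unreadable from compound 1 to compound 3. In this assay, compound 3 is estimated at 60 ug/mL, with an expected range from 30 ug/mL to 110 ug/mL.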

Compound 3, half-maximal cytotoxic concentration: > 50 ug/mL
Compound 3 was reported as a limit; the forecaster's own chance of this, stated with the estimate: 75%; the middle value does not contradict the limit.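

Like compound 1, compound 3 gives only a limit of the assay and not a number in this assay, so no step can be read for phenyl in place of 2,5-difluorophenyl. The record now reads: the limit of > 50 ug/mL in this assay, at which 3 of the 3 values shown sit. The compounds shown leave open what concentration harms these cells, and whether any structural change shifts it.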